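Aryl urea series: acetyl to bromo on the anilide ring

This account rests on a few compounds, and the source may have more. Where it says the series, first, only, none or still open, it means among the compounds named here.

Three ureas on a shared core have been run in an ADME assay on the whole organism with Oryza sativa as the target, tested at 0.1 uM; a higher number here means a weaker effect of the compound at the concentration tested, a lower number a stronger effect. Compound 1 `CC(C)c1cccc(NC(=O)N[C@H](C)c2ccccc2)c1` gives 74%. Compound 2 `COc1cccc(NC(=O)N[C@H](C)c2ccccc2)c1` gives 104%, and compound 3 `CC(=O)c1cccc(NC(=O)N[C@H](C)c2ccccc2)c1` gives 98%. Among these numbers compound 3 stands second highest: one step is a number 6 percentage points lower from compound 2 to compound 3 (within the scatter), whereas the other is a number 24 percentage points higher from compound 1 to compound 3 (beyond the scatter), so only compound 1 is set apart from the other two.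

Compound 4 `C[C@@H](NC(=O)Nc1cccc(Br)c1)c1ccccc1` is not yet measured. It differs from compound 3 by bromo in place of acetyl on an aromatic carbon. All three measured steps exchange the group on the same aromatic carbon and so bear on this change: a number 30 percentage points higher from compound 1 to compound 2 (beyond the scatter), a number 24 percentage points higher from compound 1 to compound 3 (beyond the scatter), and a number 6 percentage points lower from compound 2 to compound 3 (within the scatter). The two larger steps both start from compound 1, while the swap between compound 2 and compound 3 stayed within the scatter. Bromo brings no hydrogen-bond acceptor, unlike the acetyl it replaces, which is the only hint pointing toward the level of compound 1. The step in this assay is expected to be a number 13 percentage points lower from compound 3 to compound 4 (beyond the scatter), a modest lowering with wide uncertainty. For compound 4 the estimate is 85%, within a range from 65% to 105%.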

Compound 4, a percentage reported as activity, at one concentration (the size of the read-out at that concentration, not a potency): 100%
Compound 4: middle estimate off by 15 percentage points, on the low side; low and high end bracket the measured number.
By their numbers in this assay, from the lowest: compound 1; then compounds 3, 4 and 2 (each within the scatter of the next).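

In this assay bromo in place of acetyl gives a number 2 percentage points higher from compound 3 to compound 4 (within the scatter) and bromo in place of methoxy gives a number 4 percentage points lower from compound 2 to compound 4 (within the scatter) so bromo, acetyl and methoxy cannot be told apart on this aromatic carbon. Bromo enters with 0 hydrogen-bond acceptors where acetyl leaves with 1, yet a number 26 percentage points higher from compound 1 to compound 4 (beyond the scatter) still separates bromo from isopropyl, so the absence of an acceptor on the group does not by itself bring a compound to the level of compound 1, and isopropyl remains the only one of the four groups set apart. No measured evidence is at hand on why isopropyl stands apart from the other three groups.

Going by these compounds, it remains open whether the lower number in this assay is particular to isopropyl or is shared by other carbon-only groups, such as ethyl, tert-butyl or cyclopropyl, on the same aromatic carbon. Also open, on these data alone, is whether an amine or a carboxylic acid at this place would stay level with compounds 2, 3 and 4, and whether the isopropyl gap holds when the rest of the shared core is changed.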